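Loss of the (1-bromoethenyl)carbonyl group on a second core

A few compounds are considered here, and "the series" means these few. Any claim that something is new, unique, unknown or untested is made for them only; others in the source may bear on it.

Compound 1 `C=C(Br)C(=O)Nc1ccc(/C=C/C(=O)c2ccc(Cl)cc2)cc1` carries a (1-bromoethenyl)carbonyl group on a nitrogen on an aromatic ring, and in a functional assay on MOLT-4 cells (Homo sapiens) for antiproliferative activity, with a stated time of 48 h (a higher number here means a weaker inhibitor, a lower number a stronger inhibitor), compound 1 gives 810 nM. Compound 3 `Nc1ccc(/C=C/C(=O)c2ccc(Cl)cc2)cc1` is the corresponding amine; the change is hydrogen in place of (1-bromoethenyl)carbonyl on a nitrogen on an aromatic ring. In this assay compound 3 gives 7800 nM, which is a 9.6-fold higher number from compound 1 to compound 3 (0.98 log units; beyond the scatter).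

Compound 2 `C=C(Br)C(=O)Nc1ccc(C(=O)/C=C/c2ccccc2)cc1` keeps the same group on a nitrogen on an aromatic ring but sits on a different core; the difference between the two cores is not broken down here. In this assay compound 2 gives 500 nM; its gap to compound 1 is within the scatter, its gap to compound 3 beyond it.

Compound 4 `Nc1ccc(C(=O)/C=C/c2ccccc2)cc1` is not yet measured. It stands to compound 2 as compound 3 stands to compound 1: hydrogen in place of (1-bromoethenyl)carbonyl on a nitrogen on an aromatic ring. The two place descriptions match word for word, so this is the same change, observed once so far. In this assay, for the measured compounds named here, compound 4 is expected to show a 9.6-fold higher number from compound 2 to compound 4 (0.98 log units; beyond the scatter), because a 9.6-fold higher number from compound 1 to compound 3 (0.98 log units; beyond the scatter) is the only precedent and no second pairing argues against carrying it over. The estimate for compound 4 in this assay is 4800 nM, likely between 1500 nM and 15000 nM.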

Compound 4, half-maximal inhibitory concentration: 7900 nM
Compound 4: middle estimate off by 1.6-fold (0.22 log units), on the low side; the range from low to high includes it.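

In this assay the loss of the (1-bromoethenyl)carbonyl group in favour of hydrogen on the second core gives a 16-fold higher number from compound 2 to compound 4 (1.20 log units; beyond the scatter), so the amines again sit well above the bromo amides. Set side by side, the two steps cannot be told apart, and on these two cores the change carries over with a similar size: the same change on two cores in this assay, a 9.6-fold higher number (0.98 log units; beyond the scatter) from compound 1 to compound 3 and a 16-fold higher number (1.20 log units; beyond the scatter) from compound 2 to compound 4, 1.6-fold (0.22 log units) apart, within the scatter of two such steps. For the compounds shown here, this rests on only two pairs, so it supports transfer between these two cores alone, gives no rule for other cores, and does not show which part of the departing group accounts for the step.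

Open, from the compounds shown here alone, is how an acetyl group or a propenoyl group without the bromine would compare on the same nitrogen, which leaves the separate shares of the bromine, the double bond and the amide unresolved. Also open, going by these compounds, is whether the step keeps its size on a core carrying a further substituent such as a methoxy group.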